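The compounds below may be only part of what the source reports. "The series", "measured", "known", "first", "only" and "open" are said of these compounds alone.

Compound 1 `O=C(NCc1ccc(S(=O)(=O)c2ccccc2)cc1)c1ccc2nccn2c1`: 13 nM
Compound 2 `O=C(NCc1ccc(S(=O)(=O)c2ccccc2)cc1)c1cn2ccnc2cn1`: > 10000 nM
Compound 3 `O=C(NCc1ccc(S(=O)(=O)c2ccccc2)cc1)c1c[nH]c2ccncc12`: 2100 nM

All three were tested in a functional assay on A2780 cells (Homo sapiens) for inhibition, read by sulforhodamine B assay, with a stated time of 72 h; a lower number here means a stronger inhibitor, a higher number a weaker inhibitor. Compound 2 reads > 10000 nM, which is a limit of the assay and not a number. Of the two real numbers, compound 3 has the higher, 2100 nM, so it is a much weaker inhibitor than compound 1.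

Compound 4 `O=C(NCc1ccc(S(=O)(=O)c2ccccc2)cc1)c1ccc2nncn2c1` has not yet been measured. Its structural change is a group of 9 heavy atoms (6 carbon, 3 nitrogen; one five-membered aromatic ring with 3 hetero atoms, one six-membered aromatic ring with 1 hetero atom) in place of a group of 9 heavy atoms (7 carbon, 2 nitrogen; one five-membered aromatic ring with 1 hetero atom, one six-membered aromatic ring with 1 hetero atom), on a carbonyl carbon. Two measured steps change the group at this same place, and both are large: a 160-fold higher number from compound 1 to compound 3 (2.21 log units; beyond the scatter) and an at least 760-fold higher number from compound 1 to compound 2 (2.88 log units; beyond the scatter). The group is therefore very sensitive to change, and a single swap can cost a great deal. Compound 4 retains the six-membered aromatic ring with 1 hetero atom, as compound 1 and compound 3 do, whereas compound 2 does not. A recovery of part of the lost inhibition seems likely, though this is uncertain. The expected move is a 7.0-fold lower number from compound 3 to compound 4 (0.85 log units; beyond the scatter), towards a lower number. For compound 4 the estimated value is 300 nM, with an expected range of 25 nM to 5000 nM.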

Compound 4, half-maximal inhibitory concentration: > 10000 nM
Compound 4: no number, only a limit; the forecaster's own chance of this, stated with the estimate: 12%; at least 33-fold (1.52 log units) between middle value and limit.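

In this assay compound 4 gives only a limit of the assay, not a number, and so does compound 2: the limit of > 10000 nM in this assay, at which 2 of the 4 values shown sit. Keeping the six-membered aromatic ring with 1 hetero atom is therefore not enough on its own, as the five-membered aromatic ring with 3 hetero atoms brings an at least 760-fold higher number from compound 1 to compound 4 (2.88 log units; beyond the scatter) and also an at least 4.7-fold higher number from compound 3 to compound 4 (0.67 log units; beyond the scatter). Among these four groups on the carbonyl carbon, only the group of compound 1 gives a strong inhibitor, and the step between compound 2 and compound 4 cannot be read.

The compounds shown do not tell which ring nitrogen in the group of compound 4 accounts for the loss. From the compounds shown here alone, whether the group of compound 1 would tolerate an added methyl group or an amine also remains open.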